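This account rests on a few compounds, and the source may have more. Where it says the series, first, only, none or still open, it means among the compounds named here.

Compound 1 `Cc1c(C(=O)N/N=C\c2ccccc2F)oc2cccc(O)c12` is examined in a functional assay on PC-3 cells (Homo sapiens) for inhibition; on this read-out lower numbers stand for stronger inhibition and higher numbers for weaker inhibition. For compound 1 the reading is only a limit of the assay, >= 40000 nM, as noted in the limit of >= 40000 nM in this assay, at which 1 of the 3 values shown sits. Compound 4 `Cc1c(C(=O)N/N=C\c2ccncc2)oc2cccc(O)c12` has not yet been measured; it differs from compound 1 in one place: pyridin-4-yl in place of 2-fluorophenyl on a carbon with a double bond to nitrogen. Two measured steps start from compound 1. Compound 2 `Cc1c(C(=O)N/N=C\c2c(O)cccc2F)oc2cccc(O)c12` gives 8050 nM, a step of an at least 4.9-fold lower number from compound 1 to compound 2 (0.69 log units; beyond the scatter). Compound 3 `Cc1ccc(O)c(/C=N\NC(=O)c2oc3cccc(O)c3c2C)c1` gives 7350 nM, a step of an at least 5.4-fold lower number from compound 1 to compound 3 (0.73 log units; beyond the scatter). Each of those steps brings in a hydroxy group, and the pyridin-4-yl entering compound 4 carries none, which leaves the change without a close precedent. The expected step is an at least 1.1-fold lower number from compound 1 to compound 4 (0.05 log units; that floor lies within the scatter). Compound 4 is estimated at 35000 nM, within 8000 nM to 100000 nM.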

Compound 4, half-maximal inhibitory concentration: >= 40000 nM
Compound 4: a limit, no number; the forecaster's own chance of this, stated with the estimate: 55%; at least 1.1-fold (0.05 log units) between middle value and limit.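

Placing pyridin-4-yl on this carbon gives an at least 5.4-fold higher number from compound 3 to compound 4 (0.73 log units; beyond the scatter) and an at least 4.9-fold higher number from compound 2 to compound 4 (0.69 log units; beyond the scatter). Among the four compounds, the two with a hydroxy group on this ring give numbers, while compound 4, whose ring nitrogen counts as a hydrogen-bond acceptor, joins compound 1 at a limit of this assay: the limit of >= 40000 nM in this assay, at which 2 of the 4 values shown sit. The step between compound 1 and compound 4 cannot be read.

As far as these compounds go, whether an amine or a carboxylic acid on a phenyl ring at this carbon could stand in for the hydroxy group remains open. So does the effect of a hydroxy group on the pyridin-4-yl ring.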